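The source may hold more compounds than are shown below. What is called first, only, known or untested is meant among the compounds shown, and "the series" means these compounds.

Compound 1 `O[C@@H](c1ccccc1)[C@H]1CO[C@H](c2ccccc2)[C@@H](C/C=C/c2cccc(F)c2)C1` in a functional assay on HL-60 cells (Homo sapiens) for cytotoxicity, read by WST assay, with a stated time of 48 h; a higher number here means a weaker inhibitor, a lower number a stronger inhibitor: 9170 nM
Compound 2 `COc1ccc(/C=C/C[C@H]2C[C@@H]([C@@H](O)c3ccccc3)CO[C@@H]2c2ccccc2)cc1` in this assay: 9010 nM

Within the data shown here, compound 2 cannot be ranked against compound 1, the only other measured compound: their two values lie within the usual scatter of repeated measurements.

The next compound, compound 3 `O[C@@H](c1ccccc1)[C@H]1CO[C@H](c2ccccc2)[C@@H](C/C=C/C2CCCC2)C1`, differs from compound 2 in one place: cyclopentyl in place of 4-methoxyphenyl on a double-bonded chain carbon bound to a double-bonded chain carbon. Put simply, this is cyclopentyl in place of 4-methoxyphenyl on a double-bonded chain carbon bound to a double-bonded chain carbon, so a non-aromatic ring replaces an aromatic one.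

Among the measured compounds shown here, only one measured step bears on this change, the one made at the same place: a 1.0-fold lower number from compound 1 to compound 2 (0.01 log units; within the scatter). That step swapped one aromatic ring for another, so the data do not show what a non-aromatic ring does here. With so little evidence, and starting from the value of compound 2, 9010 nM, no step beyond the scatter is expected in this assay, and neither direction is favoured.

The expected step is a 1.0-fold lower number from compound 2 to compound 3 (0.00 log units; within the scatter). For compound 3 the estimated value is 9000 nM, with an expected range from 4000 nM to 20000 nM.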

Compound 3, half-maximal inhibitory concentration: 9060 nM
Compound 3: middle estimate off by 1.0-fold (0.00 log units), on the low side; measured number inside the range.
By their numbers in this assay, from the lowest: compounds 2, 3 and 1 (each within the scatter of the next).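

Until now this place had only seen one aromatic ring exchanged for another, and compound 3 extends the comparison to a non-aromatic ring: cyclopentyl in place of 4-methoxyphenyl gives a 1.0-fold higher number from compound 2 to compound 3 (0.00 log units; within the scatter) and cyclopentyl in place of 3-fluorophenyl gives a 1.0-fold lower number from compound 1 to compound 3 (0.01 log units; within the scatter) in this assay and both steps lie within the scatter. So the aromatic ring and the hydrogen-bond acceptor of 4-methoxyphenyl can both be absent here, and the group can go from 8 heavy atoms to 5, without a difference that can be told from the scatter. Nothing measured here explains why these numbers stay together.

The compounds shown leave open whether an amine or a carboxylic acid on this chain carbon would move the number beyond the scatter. They also leave open what a longer chain would do in place of the present one, and whether any group at this place can shift the number at all.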